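A few compounds are considered here, and "the series" means these few. Any claim that something is new, unique, unknown or untested is made for them only; others in the source may bear on it.

Compound 3 `CCCCCC/C(=N\OC)c1cc(OC)c2c(c1OC)C(=O)C=CC2=O` stands at a limit of a functional assay on A549 cells (Homo sapiens) for antiproliferative activity; on this read-out higher numbers stand for an effect only at larger amounts of compound and lower numbers for an effect already at smaller amounts: in this assay compound 3 gives > 10 ug/mL, a limit rather than a number. Compound 1 `CCCCCC/C(=N\OCCCCC)c1cc(OC)c2c(c1OC)C(=O)C=CC2=O` likewise gives only the limit > 10 ug/mL. Compound 2 `CO/N=C/c1cc(OC)c2c(c1OC)C(=O)C=CC2=O` also gives only the limit > 10 ug/mL. Going by the values given here, the one measured step, a step that the two limits leave unreadable from compound 1 to compound 3, is therefore unreadable, and the limit of > 10 ug/mL in this assay, at which 3 of the 3 values shown sit, shows that every value shown sits at the same limit. Compound 4 `CCCCCC/C(=N\OCCC)c1cc(OC)c2c(c1OC)C(=O)C=CC2=O` differs from compound 3 by ethyl in place of hydrogen on a saturated chain carbon bound to an oxygen. Among the compounds with values here, no measured step tells the size or direction of this change, so nothing beyond the scatter can be expected in this assay. Compound 4 is therefore estimated at 15 ug/mL, between 8 ug/mL and 40 ug/mL. That estimate means a step that the limit leaves unreadable from compound 3 to compound 4, expected to stay within the scatter.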

Compound 4, concentration for half-maximal effect: > 10 ug/mL
Compound 4: a limit, no number; the forecaster's own chance of this, stated with the estimate: 75%; the middle value is on the limit's open side.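

No new step can be read among compound 1, compound 3 and compound 4, as all remain limits: the limit of > 10 ug/mL in this assay, at which 4 of the 4 values shown sit. The compounds shown leave open whether any of these chain changes alters the read-out in this assay.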